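A few compounds are considered here, and "the series" means these few. Any claim that something is new, unique, unknown or untested is made for them only; others in the source may bear on it.

Compound 1 `C[C@H](c1ccc(C(=O)NCCC(=O)O)cc1)N1C(=O)C(c2cccc(C3CC3)c2)=N[C@]12CC[C@@H](C(C)(C)C)CC2`: 56 nM
Compound 2 `CC(C)(C)CC[C@H](c1ccc(C(=O)NCc2nn[nH]n2)cc1)N1C(=O)C(c2cncc(Cl)c2)=N[C@]12CC[C@@H](C(C)(C)C)CC2`: 38 nM
Compound 3 `CC(C)(C)CC[C@H](c1ccc(C(=O)NCc2nn[nH]n2)cc1)N1C(=O)C(c2cccc(C(F)(F)F)c2)=N[C@]12CC[C@@H](C(C)(C)C)CC2`: 13 nM

In an assay on CHO cells for displacement of a labelled ligand from Glucagon receptor (Homo sapiens), read by scintillation counting, with a stated time of 60 min (a higher number here means a weaker inhibitor, a lower number a stronger inhibitor), compound 1 stands at the highest of the three numbers. Its nearest neighbour is compound 2, and that gap lies within the scatter; compound 3 lies furthest from it, beyond the scatter. Within the data shown here, compound 2 and compound 3 differ from compound 1 in the acid-bearing side chain and the substituent on the benzylic carbon as well, so none of the measured pairs is a single-point change from compound 1.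

Compound 4 `C[C@H](c1ccc(C(=O)NCCC(=O)O)cc1)N1C(=O)C(c2cccc(OC(F)(F)F)c2)=N[C@]12CC[C@@H](C(C)(C)C)CC2` differs from compound 1 in one place: trifluoromethoxy in place of cyclopropyl on an aromatic carbon. Among the measured compounds shown here, the only measured step at this position is the swap of the aryl group on the carbon with a double bond to nitrogen, a 2.9-fold lower number from compound 2 to compound 3 (0.47 log units; beyond the scatter), a modest step between two groups of which neither is cyclopropyl or trifluoromethoxy, on a pair whose remaining substituents also differ from those of compound 1. For the measured compounds named here, the change from cyclopropyl to trifluoromethoxy is therefore not covered by any measured step; what the data show is only that the compound carrying a fluorinated aryl group, compound 3, gives the lowest number. On that basis a small lowering, within or just beyond the scatter, is expected for compound 4, a 1.5-fold lower number from compound 1 to compound 4 (0.17 log units; within the scatter). The estimate for compound 4 in this assay is 38 nM, with a range from 14 nM to 105 nM.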

Compound 4, half-maximal inhibitory concentration: 330 nM
Beside the measured number, compound 4's estimate is 8.7-fold (0.94 log units) below it, and the stated range ends below it.
By their numbers in this assay, from the lowest: compound 3; then compounds 2 and 1 (each within the scatter of the next); then compound 4.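

In this assay, among these compounds, the change from 3-cyclopropylphenyl to 3-(trifluoromethoxy)phenyl gives a 5.9-fold higher number from compound 1 to compound 4 (0.77 log units; beyond the scatter) and is the first step in which this aryl substituent changes while the rest of the structure stays fixed, so the number responds to the group on this aromatic carbon on its own. Among the compounds shown here, the only earlier step on this aryl group, a 2.9-fold lower number from compound 2 to compound 3 (0.47 log units; beyond the scatter) in the same direction of fluorine entering, ran downward on different remaining substituents, so the entry of a fluorine-bearing group does not by itself fix the direction of the change, with compound 3 lowering the number and compound 4 raising it. Nothing available bears on the reason for the rise from compound 1 to compound 4.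

As far as these compounds go, whether methyl, methoxy, a nitrile or an amine on this aromatic carbon would stay close to compound 1 or move the number as far as trifluoromethoxy does remains open. Also open, from the compounds shown here alone, is whether the same swap keeps its size when the remaining substituents are those of compound 3.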